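Bromo in place of fluoro on compound 1

The compounds below may be only part of what the source reports. "The series", "measured", "known", "first", "only" and "open" are said of these compounds alone.

In a functional assay on SGC-7901 cells (Homo sapiens) for inhibition, read by MTT assay, with a stated time of 72 h (on this read-out lower numbers stand for stronger inhibition and higher numbers for weaker inhibition), compound 1 `O=C(NCc1ccc(NC(=O)c2cc(F)ccc2N2CCCC2)cc1)OCc1cccnc1` gives 44800 nM while compound 2 `O=C(NCc1ccc(NC(=O)c2ccc(F)cc2N2CCCC2)cc1)OCc1cccnc1` gives 56200 nM and compound 3 `Cc1ccc(C(=O)Nc2ccc(CNC(=O)OCc3cccnc3)cc2)c(N2CCCC2)c1` gives 75200 nM on the same read-out. On these numbers compound 1 lies within the scatter of both others. The change to compound 4 `O=C(NCc1ccc(NC(=O)c2cc(Br)ccc2N2CCCC2)cc1)OCc1cccnc1` is bromo in place of fluoro on an aromatic carbon, para to a pyrrolidin-1-yl group (bromo in place of fluoro on an aromatic carbon). For the measured compounds named here, the one measured step that bears on it, methyl in place of fluoro, is a 1.3-fold higher number from compound 2 to compound 3 (0.13 log units; within the scatter) and offers only indirect guidance. Going by the values given here, no measured step involves bromo. In this assay no shift beyond the scatter is expected, the estimated step being a 1.1-fold higher number from compound 1 to compound 4 (0.05 log units; within the scatter) in size. For compound 4 the estimate is 50000 nM (expected range 25000 nM to 100000 nM)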

Compound 4, half-maximal inhibitory concentration: > 100000 nM
Compound 4 gave a limit, no number; the forecaster's own chance of this, stated with the estimate: 10%; middle value at least 2.0-fold (0.30 log units) away from the limit.
By their numbers in this assay, from the lowest: compounds 1, 2 and 3 (each within the scatter of the next). At a limit, above all of these: compound 4.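

In this assay, the aromatic carbon para to a pyrrolidin-1-yl group does not tolerate every halogen equally: bromo in place of fluoro gives an at least 2.2-fold higher number from compound 1 to compound 4 (0.34 log units; beyond the scatter), the only step shown that lies beyond the scatter. Compound 4 gives a limit and not a number, so this step has a lower bound only: the limit of > 100000 nM in this assay, at which 1 of the 4 values shown sits.

On these data alone, it remains open whether chloro, methyl or an amine at this position would stay close to compound 1 or move towards compound 4. Also open, as far as these compounds go, is whether bromo at the fluoro-bearing carbon of compound 2 would produce a similar step.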